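The source may hold more compounds than are shown below. What is called first, only, known or untested is meant among the compounds shown, and "the series" means these compounds.

Compounds so far:
Compound 1 `N#Cc1c(O)nc(SCc2nc3ccccc3[nH]2)nc1-c1ccccc1`: 4.63 nM
Compound 2 `N#Cc1c(NNC(N)=S)nc(SCc2nc3ccccc3[nH]2)nc1-c1ccccc1`: 8.9 nM
Compound 3 `N#Cc1c(NC(N)=S)nc(SCc2nc3ccccc3[nH]2)nc1-c1ccccc1`: not yet measured

In a functional assay on K562 cells (Homo sapiens) for cytotoxicity, read by MTT assay, with a stated time of 3 days (a lower number here means a stronger inhibitor, a higher number a weaker inhibitor), compound 2 gives 8.9 nM. Among the compounds with values here, compound 1 gives 4.63 nM in the same test, so the two numbers cannot be told apart and compound 2 stands level with the only other measured compound.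

The next change, from compound 2 to compound 3, is a group of 3 heavy atoms (1 carbon, 1 nitrogen, 1 sulfur; no ring) in place of a group of 4 heavy atoms (1 carbon, 2 nitrogen, 1 sulfur; no ring), on a nitrogen on an aromatic ring. It is a small exchange, on a nitrogen on an aromatic ring, and the rest of the structure stays as it is.

Within the data shown here, only one measured step bears on it: a 1.9-fold higher number from compound 1 to compound 2 (0.28 log units; within the scatter). That step put a group of 5 heavy atoms in place of one oxygen atom and stayed within the scatter. The exchange now in question has not itself been measured, and a single step is thin support. Even so, nothing measured points to a shift beyond the scatter in this assay, and no direction is favoured.

The expected step is a 1.2-fold lower number from compound 2 to compound 3 (0.07 log units; within the scatter). For compound 3 the estimated value is 7.5 nM, with an expected range of 2.5 nM to 25 nM.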

Compound 3, half-maximal inhibitory concentration: 11.9 nM
Estimate against measurement, compound 3: 1.6-fold (0.20 log units) below, and the stated range covers the measured number.
By their numbers in this assay, from the lowest: compounds 1, 2 and 3 (each within the scatter of the next, the first and the last beyond it).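

In this assay, the group of 3 heavy atoms in place of the group of 4 heavy atoms, on a nitrogen on an aromatic ring, gives a 1.3-fold higher number from compound 2 to compound 3 (0.13 log units; within the scatter), so this exchange on the nitrogen leaves the number indistinguishable. Within the data shown here, at the aromatic carbon that carries the oxygen in compound 1, a 2.6-fold higher number from compound 1 to compound 3 (0.41 log units; beyond the scatter) is the first step at this position to pass the scatter, though only modestly, whereas the larger group of compound 2 gave a 1.9-fold higher number from compound 1 to compound 2 (0.28 log units; within the scatter). Since compound 2 and compound 3 cannot be told apart, these steps show no clean trend with the size of the group, and no measurement is available to explain the small separation of compound 3 from compound 1.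

On these data alone, it remains open how a plain amine or a methoxy group on that aromatic carbon would compare with the oxygen of compound 1 in this assay. A longer chain on the nitrogen, such as an ethyl-substituted version of the group in compound 3, would show whether this position continues to tolerate change.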